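The compounds below may be only part of what the source reports. "The series", "measured", "known", "first", "only" and "open" are said of these compounds alone.

Compound 1 `COC(=O)N[C@H](C(=O)NN(CCC[C@@](O)(Cc1ccccc1)C(=O)N[C@H]1c2ccccc2C[C@H]1O)Cc1ccc(Br)cc1)C(C)(C)C` is the starting point in an ADME assay on MT4 cells (Homo sapiens) for cytotoxicity; a lower number here means that less compound is tolerated, a higher number that more compound is tolerated. In this assay compound 1 gives only a limit, > 10000 nM. Two related compounds sit at the same limit. Compound 2 `COC(=O)N[C@H](C(=O)NN(CCC[C@@](O)(Cc1ccccc1)C(=O)N[C@H]1c2ccccc2C[C@H]1O)Cc1ccc(-n2ccnc2)cc1)C(C)(C)C` gives a limit of > 10000 nM in this assay. Compound 3 `COC(=O)N[C@H](C(=O)NN(CCC[C@@](O)(Cc1ccccc1)C(=O)N[C@H]1c2ccccc2C[C@H]1O)Cc1ccc(-c2nccs2)cc1)C(C)(C)C` gives a limit of > 10000 nM in this assay. Going by these compounds, because every value shown sits at the limit of > 10000 nM in this assay, at which 3 of the 3 values shown sit, none of the steps among them has a readable size: a step that the two limits leave unreadable from compound 1 to compound 2, a step that the two limits leave unreadable from compound 1 to compound 3 and a step that the two limits leave unreadable from compound 2 to compound 3 all remain open. Compound 1 therefore stands at the limit of this assay, with no number that would place it against the other two.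

Compound 4 `COC(=O)N[C@H](C(=O)NN(CCC[C@@](O)(Cc1ccccc1)C(=O)N[C@H]1c2ccccc2C[C@H]1O)Cc1ccc(-c2nc(C(C)(C)C)cs2)cc1)C(C)(C)C` differs from compound 1 in one place: 4-(tert-butyl)-1,3-thiazol-2-yl in place of bromo on an aromatic carbon. The two steps that bear on this change, both of which exchanged bromo for a five-membered aromatic ring, left their values at the limit, so no size for this assay can be drawn from them. The expectation is therefore that compound 4 also sits at the limit, with no readable step, a step that the limit leaves unreadable from compound 1 to compound 4. Compound 4 is estimated at 15000 nM in this assay, within a range of 7000 nM to 40000 nM.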

Compound 4, half-maximal cytotoxic concentration: > 10000 nM
Compound 4 was reported as a limit (the forecaster's own chance of this, stated with the estimate: 85%); the middle value does not contradict the limit.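

In this assay compound 4 gives > 10000 nM as a limit of the assay. Within the data shown here, no step among compound 1, compound 2, compound 3 and compound 4 can be read, because all of their values stand at one limit: the limit of > 10000 nM in this assay, at which 4 of the 4 values shown sit. The compounds shown leave open how far the four lie from one another, and whether any group at this place would change the tolerated concentration.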